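Removing a Chloro Group: Compound 3 to Compound 4

The source may hold more compounds than are shown below. What is called first, only, known or untested is meant among the compounds shown, and "the series" means these compounds.

For the measured compounds named here, compound 3 `Cc1cn([C@@H]2C[C@H](c3ccccc3Cl)N(C)O2)c(=O)[nH]c1=O` is the only member of this set with a measured number: in a functional assay on Jurkat cells (Homo sapiens) for cytotoxicity, read by MTT assay, with a stated time of 72 h (on this read-out lower numbers stand for stronger inhibition and higher numbers for weaker inhibition), compound 3 gives 8800 nM. The other two values are limits rather than numbers. Compound 1 `CN1O[C@@H](n2ccc(N)nc2=O)C[C@@H]1c1ccccc1` reaches only the limit > 100000 nM in this assay. Compound 2 `CN1O[C@@H](n2ccc(N)nc2=O)C[C@H]1c1ccccc1` likewise reaches only the limit > 100000 nM. The step that the two limits leave unreadable from compound 1 to compound 2 cannot be read, and this follows from the limit of > 100000 nM in this assay, at which 2 of the 3 values shown sit, together with the fact that compounds 1 and 2 differ only in the configuration as drawn.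

Compound 4 `Cc1cn([C@@H]2C[C@H](c3ccccc3)N(C)O2)c(=O)[nH]c1=O` has not yet been measured. It differs from compound 3 in one place: hydrogen in place of chloro on an aromatic carbon. Going by the values given here, none of the measured steps concerns this kind of change, so no measured step gives its size or direction. Compounds 1 and 2 also carry a phenyl rather than a 2-chlorophenyl and show only limits, but they differ from compound 3 in more than this one place, so their values cannot be turned into a step.

The expectation for compound 4 therefore stays close to the value of compound 3, with a wide range leaning toward weaker inhibition. Compound 4 is estimated at 20000 nM, between 5000 nM and 100000 nM. The step this estimate means, a 2.3-fold higher number from compound 3 to compound 4 (0.36 log units; beyond the scatter), is expected to be modest but uncertain, with a real chance that only a limit is reported.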

Compound 4, half-maximal inhibitory concentration: 76600 nM
Compound 4: the middle estimate sits 3.8-fold (0.58 log units) below what was measured; the measured number falls inside the stated range.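

In this assay, putting hydrogen in place of chloro on an aromatic carbon, ortho to a large group, gives an 8.7-fold higher number from compound 3 to compound 4 (0.94 log units; beyond the scatter) and so shows that this single atom matters in this pair. The 2-chlorophenyl compound inhibits more strongly than its phenyl partner, yet the phenyl compound still gives a real number rather than a limit, so losing the chloro group weakens this read-out without removing a measurable effect. The step between compound 1 and compound 2 still cannot be read, which leaves this pair as the only readable measure of any change in the set.

From the compounds shown here alone, whether another group at this place, such as fluoro, bromo, methyl or methoxy, would match the chloro group or go beyond it stays open, as does whether a chloro group at the same place would make a similar difference on the core of compound 1. What lies behind the step also stays open, since nothing shown speaks to it.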